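Replacing the amino group of compound 1 on the aryl ring

The source may hold more compounds than are shown below. What is called first, only, known or untested is meant among the compounds shown, and "the series" means these compounds.

Measured in a functional assay on the whole organism (strain Sprague-Dawley) for inhibition, with Rattus norvegicus as the target, with a stated time of 10 min (on this read-out lower numbers stand for an effect already at smaller amounts and higher numbers for an effect only at larger amounts of compound), so far:
- compound 1 `Nc1ccccc1-c1ncc(C(=O)O)c(=O)[nH]1` gives 50 mg/kg
- compound 2 `CC(C)Oc1ccccc1-c1ncc(C(=O)O)c(=O)[nH]1` gives 0.8 mg/kg
- compound 3 `CCC(C)Oc1ccccc1-c1ncc(C(=O)O)c(=O)[nH]1` gives 0.5 mg/kg

Compound 1 stands at the highest of the three numbers. Its nearest neighbour is compound 2, reached by a 63-fold lower number from compound 1 to compound 2 (1.80 log units; beyond the scatter); the furthest is compound 3, reached by a 100-fold lower number from compound 1 to compound 3 (2.00 log units; beyond the scatter). Between the two ether compounds the difference is small: a 1.6-fold lower number from compound 2 to compound 3 (0.20 log units; within the scatter).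

Compound 4 `CCSc1ccccc1-c1ncc(C(=O)O)c(=O)[nH]1` differs from compound 1 as follows: ethylsulfanyl in place of amino on an aromatic carbon. Among the measured compounds shown here, the steps that bear on this change are those from compound 1 to compound 2 and from compound 1 to compound 3, where the amino group on the same aromatic carbon gave way to an alkoxy chain and the number fell by a large margin in both cases. For the measured compounds named here, the ethylsulfanyl group is again a short chain carrying an acceptor and no donor in that position, so a large drop in this assay is expected for compound 4 as well, though with no sulfur analogue measured the size is less certain than for the ethers. The expected step is a 33-fold lower number from compound 1 to compound 4 (1.52 log units; beyond the scatter). Compound 4 is therefore estimated at 1.5 mg/kg, with a range from 0.4 mg/kg to 6 mg/kg.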

Compound 4, dose for 50% inhibition: 25 mg/kg
Compound 4: middle estimate off by 17-fold (1.22 log units), on the low side; the whole stated range lies below it.
By their numbers in this assay, from the lowest: compounds 3 and 2 (each within the scatter of the next); then compounds 4 and 1 (each within the scatter of the next).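

In this assay ethylsulfanyl on this aromatic carbon does not behave like the alkoxy chains: a 2.0-fold lower number from compound 1 to compound 4 (0.30 log units; within the scatter) leaves compound 4 indistinguishable from the amino compound, while a 31-fold higher number from compound 2 to compound 4 (1.49 log units; beyond the scatter) and a 50-fold higher number from compound 3 to compound 4 (1.70 log units; beyond the scatter) set it well apart from both ethers. Losing the amino group's hydrogen-bond donor is therefore not enough on its own for a large step here, as ethylsulfanyl has 0 hydrogen-bond donors and yet no such step appears. No measurement at hand accounts for the gap between the ethers and ethylsulfanyl.

Ethylsulfanyl differs from isopropoxy and sec-butoxy in both the sulfur and the chain, so the two remain unseparated. Ethoxy and isopropylsulfanyl on this aromatic carbon would tell whether the gap follows the sulfur or the shape of the chain.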